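A few compounds are considered here, and "the series" means these few. Any claim that something is new, unique, unknown or untested is made for them only; others in the source may bear on it.

Values in a functional assay on HOS-TE85 cells (Homo sapiens) for inhibition, read by CCK-8 assay, with a stated time of 72 h; on this read-out lower numbers stand for stronger inhibition and higher numbers for weaker inhibition:
compound 1 `COc1ccc(F)cc1N1C(=O)CSC1c1cccc(C(=O)NCCCCn2cccn2)c1`: 97.3 nM
compound 2 `COc1ccccc1N1C(=O)CSC1c1cccc(C(=O)NCCCCn2cncn2)c1`: > 1000 nM
compound 3 `O=C(NCCCCn1cccn1)c1cccc(C2SCC(=O)N2c2cc(Br)ccn2)c1`: 105 nM

The entry for compound 2, > 1000 nM, is a limit of the assay and not a number.

In this assay compound 3 gives 105 nM, within the scatter of compound 1 at 97.3 nM, so these two numbers cannot be ordered.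

The next analogue is compound 4 `Cc1ccnc(N2C(=O)CSC2c2cccc(C(=O)NCCCCn3cccn3)c2)c1`, which carries methyl in place of bromo on an aromatic carbon, opposite the ring nitrogen: methyl in place of bromo on an aromatic carbon. This exact exchange has not been measured in the series. The nearest evidence is a larger replacement of the group on the amide-type nitrogen, a 1.1-fold higher number from compound 1 to compound 3 (0.03 log units; within the scatter). That single step stays within the scatter, so no shift beyond the scatter is expected here, and no direction can be assigned.

The expected move is a 1.1-fold higher number from compound 3 to compound 4 (0.06 log units; within the scatter).

For compound 4 the estimated value is 120 nM, with an expected range of 40 nM to 360 nM.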

Compound 4, half-maximal inhibitory concentration: 19.6 nM
The estimate for compound 4 lay 6.1-fold (0.79 log units) above the measured number, outside the stated range (below it).
By their numbers in this assay, from the lowest: compound 4; then compounds 1 and 3 (each within the scatter of the next). At a limit, above all of these: compound 2.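

In this assay, the group opposite the ring nitrogen proves to be a sensitive point: methyl in place of bromo gives a 5.4-fold lower number from compound 3 to compound 4 (0.73 log units; beyond the scatter), a shift beyond the scatter from a change of one heavy atom. This separates the 4-methylpyridin-2-yl compound from the 5-fluoro-2-methoxyphenyl compound as well, with a 5.0-fold lower number from compound 1 to compound 4 (0.70 log units; beyond the scatter), whereas the 4-bromopyridin-2-yl group had shown no such separation in a 1.1-fold higher number from compound 1 to compound 3 (0.03 log units; within the scatter). No measurement shown here accounts for the difference between bromo and methyl at this position.

Going by these compounds, whether the trend extends to other groups at this position, such as chloro, trifluoromethyl or an amine, remains open. Compound 2 gives > 1000 nM, which is a limit and not a number. On these data alone, compound 2 differs from compound 1 in more than one place, so the contribution of each difference remains open too.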